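Phenyl for methyl on two related cores

The source may report more compounds than this note shows. Statements on the series, on what has been measured and on what is new or still open speak of the compounds shown alone.

Compound 1 `COc1ccc(/C=N/Nc2nc(C)cs2)cc1` is the reference point of this set. In an assay on mitochondria for inhibition of Amine oxidase [flavin-containing] B (Bos taurus) (on this read-out lower numbers stand for stronger inhibition and higher numbers for weaker inhibition), compound 1 gives 4.07 nM. Compound 2 `COc1ccc(/C=N/Nc2nc(-c3ccccc3)cs2)cc1` carries the change phenyl in place of methyl on an aromatic carbon on the core of compound 1, and in this assay compound 2 gives 132 nM. The step of a 32-fold higher number from compound 1 to compound 2 (1.51 log units; beyond the scatter) is the only measured step of this kind in the set.

Compound 3 `Cc1ccc(/C=N/c2nc(C)cs2)cc1` stands on a different core; how the core of compound 3 differs from the core of compound 1 is not broken down here. In this assay compound 3 gives 832 nM, the highest of the three numbers, and its distance from compound 1 and from compound 2 is in each case beyond the scatter.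

Compound 4 `Cc1ccc(/C=N/c2nc(-c3ccccc3)cs2)cc1` is not yet measured. It carries the change phenyl in place of methyl on an aromatic carbon on the core of compound 3. The surroundings of the place are not word for word the same as for the earlier pair: there the ring atom two ring bonds away bears a large group, here a group of 9 heavy atoms, so this is the same kind of change rather than the same change.

With one earlier example on a different core, the expected step from compound 3 to compound 4 is taken as an 18-fold higher number from compound 3 to compound 4 (1.26 log units; beyond the scatter), somewhat smaller than a 32-fold higher number from compound 1 to compound 2 (1.51 log units; beyond the scatter) and with wide uncertainty, because the core of compound 3 already sits at 832 nM. Compound 4 is therefore estimated at 15000 nM in this assay, within 3000 nM to 80000 nM.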

Compound 4, inhibition constant: 0.813 nM
Compound 4: the middle estimate sits 18000-fold (4.27 log units) above what was measured; the whole stated range lies above it.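

In this assay, the step of a 1000-fold lower number from compound 3 to compound 4 (3.01 log units; beyond the scatter) runs in the opposite direction to the step on the core of compound 1, so phenyl in place of methyl on an aromatic carbon does not carry over from one core to the other in this series. Set side by side, the two steps differ in direction as well as size: the same change on two cores in this assay, a 32-fold higher number (1.51 log units; beyond the scatter) from compound 1 to compound 2 and a 1000-fold lower number (3.01 log units; beyond the scatter) from compound 3 to compound 4, 33000-fold (4.52 log units) apart, beyond the scatter of two such steps. This shows that, for these four compounds, the outcome of the change depends on the core it is made on, but with a single pair on each core it does not show which feature of the core is responsible, nor what the same change would do on a third core.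

From the compounds shown here alone, it remains open whether the reversal is specific to phenyl or also appears with other groups at this place, such as a longer chain, an amine or a carboxylic acid, on each of the two cores. Also open, going by these compounds, is how the phenyl step would behave if the core of compound 1 and the core of compound 3 were bridged one difference at a time, with a methoxy or a methyl group on the far ring tested on each linker separately.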